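Benzylamino in place of dimethylamino on a carbonyl carbon

The source may report more compounds than this note shows. Statements on the series, on what has been measured and on what is new or still open speak of the compounds shown alone.

Of the compounds shown here, two on the shared core have been measured so far. In an ADME assay on CCRF-CEM cells (Homo sapiens) for cytotoxicity, with a stated time of 4 days (a higher number here means that more compound is tolerated, a lower number that less compound is tolerated), compound 1 (`Cc1cn([C@@H]2O[C@H](CO[Si](C)(C)C(C)(C)C)[C@@]3(OS(=O)(=O)C=C3N)[C@H]2O[Si](C)(C)C(C)(C)C)c(=O)n(C(=O)C2CC2)c1=O`) gives 11000 nM, and compound 2 (`Cc1cn([C@@H]2O[C@H](CO[Si](C)(C)C(C)(C)C)[C@@]3(OS(=O)(=O)C=C3N)[C@H]2O[Si](C)(C)C(C)(C)C)c(=O)n(C(=O)CCCC(=O)N(C)C)c1=O`) gives 9500 nM. Among the compounds with values here, these two numbers lie within the scatter of each other, so compound 2 cannot be separated from its only neighbour.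

Compound 3 (`Cc1cn([C@@H]2O[C@H](CO[Si](C)(C)C(C)(C)C)[C@@]3(OS(=O)(=O)C=C3N)[C@H]2O[Si](C)(C)C(C)(C)C)c(=O)n(C(=O)CCCC(=O)NCc2ccccc2)c1=O`) is the next to be read against compound 2. The change is benzylamino in place of dimethylamino on a carbonyl carbon. Cut one bond further out, this reads dimethylcarbamoyl to benzylcarbamoyl.

Within the data shown here, one measured step bears on it: a 1.2-fold lower number from compound 1 to compound 2 (0.06 log units; within the scatter). That step put 3-(dimethylcarbamoyl)propyl in place of cyclopropyl on a carbonyl carbon, and it stayed within the scatter. Among the measured compounds shown here, it is weak evidence, since no measured compound carries benzylamino or any six-membered aromatic ring at this place.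

On that single step, no shift beyond the scatter is expected in this assay, and the expected step is a 1.2-fold lower number from compound 2 to compound 3 (0.07 log units; within the scatter). Compound 3 is estimated at 8000 nM, with an expected range from 3500 nM to 18000 nM.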

Compound 3, half-maximal cytotoxic concentration: 8800 nM
Beside the measured number, compound 3's estimate is 1.1-fold (0.04 log units) below it, within the range that was stated.
By their numbers in this assay, from the lowest: compounds 3, 2 and 1 (each within the scatter of the next).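

On a carbonyl carbon whose other neighbour is a saturated chain carbon, benzylamino in place of dimethylamino gives a 1.1-fold lower number from compound 2 to compound 3 (0.03 log units; within the scatter) in this assay. The earlier step concerned only the whole group on the carbonyl carbon, cyclopropyl against 3-(dimethylcarbamoyl)propyl; this one shows that, with the chain held constant, a six-membered aromatic ring of carbon only and a hydrogen-bond donor can enter at the amide without a difference that can be separated from the scatter of this read-out. Within the data shown here, the single step covers this one exchange on this one chain, and no measurement at hand offers an explanation for the absence of a shift.

Still open, going by these compounds, is whether any group at this place moves the number beyond the scatter, for example hydroxy in place of benzylamino on this carbonyl carbon, which would give a carboxylic acid, or a primary amine in place of the benzylcarbamoyl group. A longer chain carrying the benzylcarbamoyl group, or a benzylamino with a fluorine on its aromatic ring, would test the same question further.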